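The compounds below may be only part of what the source reports. "The series", "measured", "known", "first", "only" and "open" are said of these compounds alone.

Of the compounds shown here, three built on one shared core have been measured in an in vitro functional assay on cells (Fibroblast) for agonist activity at Alpha-1A adrenergic receptor (Homo sapiens); on this read-out lower numbers stand for an effect already at smaller amounts and higher numbers for an effect only at larger amounts of compound. Compound 1 `c1ccc(-c2nc[nH]n2)c(NCC2=NCCN2)c1` gives 0.794 nM in this assay. Compound 2 `Cn1ncnc1-c1ccccc1NCC1=NCCN1` gives 2 nM, and compound 3 `CCn1ncnc1-c1ccccc1NCC1=NCCN1` gives 1.26 nM. Of these three numbers, compound 2 stands highest: there is a 2.5-fold higher number from compound 1 to compound 2 (0.40 log units; beyond the scatter), and there is a 1.6-fold lower number from compound 2 to compound 3 (0.20 log units; within the scatter).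

Compound 4 `CCCn1ncnc1-c1ccccc1NCC1=NCCN1` has not yet been measured. It differs from compound 2 in one place: ethyl in place of hydrogen on a saturated chain carbon bound to an aromatic nitrogen. Among the measured compounds shown here, only one measured step touches this same place, the one from compound 2 to compound 3, in which a methyl entered where a hydrogen had been, and that step stayed within the usual scatter of this assay. The step from compound 1 to compound 2 changes a different part of the molecule and so says little about a longer chain at this position. For the measured compounds named here, with one small step at this place as the only guide, the expectation is for at most a small move, if anything toward a lower number, and not one that clearly exceeds the scatter. Compound 4 is therefore expected to give 1.4 nM, within a range of 0.5 nM to 4 nM. This estimate corresponds to an expected step of a 1.4-fold lower number from compound 2 to compound 4 (0.15 log units; within the scatter).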

Compound 4, half-maximal effective concentration: 12.6 nM
Compound 4: middle estimate off by 9.0-fold (0.95 log units), on the low side, outside the stated range (above it).
By their numbers in this assay, from the lowest: compounds 1, 3 and 2 (each within the scatter of the next, the first and the last beyond it); then compound 4.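

In this assay, among the compounds shown here, the place on a saturated chain carbon bound to an aromatic nitrogen proves sensitive to chain length, which the earlier compounds did not reveal: a 1.6-fold lower number from compound 2 to compound 3 (0.20 log units; within the scatter) had suggested that a small extension changes little, yet the ethyl in place of hydrogen gives a 6.3-fold higher number from compound 2 to compound 4 (0.80 log units; beyond the scatter). Most of that change comes with the last carbon alone, since the methyl in place of hydrogen, two bonds along the chain from the aromatic nitrogen, gives a 10-fold higher number from compound 3 to compound 4 (1.00 log units; beyond the scatter), so the response to lengthening this chain is not even from one carbon to the next. Nothing available here explains why the number rises so sharply at this chain length.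

A longer chain such as butyl could show whether the number keeps rising or levels off, while a branched isopropyl group or a cyclopropyl ring could show whether the length of the chain or simply the number of its carbons matters. A hydroxyl group or an amine at the end of the propyl chain would test whether this place accepts a chain of that length when it carries something other than carbon and hydrogen.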